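The source may report more compounds than this note shows. Statements on the series, on what has been measured and on what is new or still open speak of the compounds shown alone.

Compounds measured in a functional assay (Pituitary gland cell) with Rattus norvegicus as the target; on this read-out higher numbers stand for an effect only at larger amounts of compound and lower numbers for an effect already at smaller amounts:
- compound 1, `CC(C)(N)CC(=O)N[C@@H]1CCc2ccccc2N(Cc2ccc(-c3ccccc3-c3nnnn3CC(=O)O)cc2)C1=O`, 1 uM
- compound 2, `Cn1nnc(-c2ccccc2-c2ccc(CN3C(=O)[C@H](NC(=O)CC(C)(C)N)CCc4ccccc43)cc2)n1`, 0.3 uM
- compound 3, `CC(O)Cn1nnnc1-c1ccccc1-c1ccc(CN2C(=O)[C@H](NC(=O)CC(C)(C)N)CCc3ccccc32)cc1`, 0.05 uM

Compound 3 holds the lowest number of the three; its nearest neighbour is compound 2, the step being a 6.0-fold lower number from compound 2 to compound 3 (0.78 log units; beyond the scatter), and the furthest is compound 1, with a 20-fold lower number from compound 1 to compound 3 (1.30 log units; beyond the scatter). Both steps lie beyond the scatter, so compound 3 is the most potent of the three on this assay.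

Compound 4, `CC(C)(N)CC(=O)N[C@@H]1CCc2ccccc2N(Cc2ccc(-c3ccccc3-c3nnnn3Cc3ccccc3)cc2)C1=O`, has not yet been measured. It differs from compound 3 by phenyl in place of 1-hydroxyethyl on a saturated chain carbon bound to an aromatic nitrogen. The change sits at the same place that all three measured steps vary: from carboxy to 1-hydroxyethyl (a 20-fold lower number from compound 1 to compound 3 (1.30 log units; beyond the scatter)), and between the two tetrazole substitution patterns (a 3.3-fold lower number from compound 1 to compound 2 (0.52 log units; beyond the scatter) and a 6.0-fold lower number from compound 2 to compound 3 (0.78 log units; beyond the scatter)). That place is clearly sensitive, and every group tried there so far keeps the compound within a span bounded by compound 1 and compound 3. Phenyl has no precedent in the set, so the direction is uncertain; the hydroxyethyl that leaves is the group that brought the largest gain, and some of that gain is expected to be lost. For compound 4 the expected step is a 3.0-fold higher number from compound 3 to compound 4 (0.48 log units; beyond the scatter). The estimate for compound 4 is 0.15 uM, within 0.03 uM to 0.7 uM.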

Compound 4, concentration for half-maximal effect: 0.7 uM
Beside the measured number, compound 4's estimate is 4.7-fold (0.67 log units) below it; low and high end bracket the measured number.
By their numbers in this assay, from the lowest: compound 3; then compound 2; then compounds 4 and 1 (each within the scatter of the next).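

In this assay, the saturated chain carbon bound to an aromatic nitrogen proves sensitive to more than the removal of carboxy: with phenyl in place of 1-hydroxyethyl there is a 14-fold higher number from compound 3 to compound 4 (1.15 log units; beyond the scatter), so the gain seen with the 2-hydroxypropyl chain does not carry over to benzyl. The 1-benzyl-1H-tetrazol-5-yl compound also falls short of the 2-methyl-2H-tetrazol-5-yl compound, with a 2.3-fold higher number from compound 2 to compound 4 (0.37 log units; beyond the scatter), which shows that a larger group does not by itself improve on a methyl. Phenyl in place of carboxy gives a 1.4-fold lower number from compound 1 to compound 4 (0.15 log units; within the scatter), within the scatter, so replacing carboxy does not bring a gain in every case, and the improvement is specific to compound 3 among the replacements shown.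

No available data explain these differences. On these data alone, it remains open whether the gain in compound 3 depends on the hydroxyl or on the saturated chain, a question that a plain propyl chain, a 2-methoxypropyl chain or a 2-aminopropyl chain would help to settle, while a longer 3-hydroxypropyl chain would test how far the hydroxyl can move.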